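This account rests on a few compounds, and the source may have more. Where it says the series, first, only, none or still open, it means among the compounds named here.

Working notes on the series. In an ADME assay on MDBK cells (Bos taurus) for cytotoxicity (on this read-out lower numbers stand for higher toxicity in this test and higher numbers for lower toxicity in this test), compound 1 `COc1ccc(Cn2ccc3nc(-c4ccccc4)nc-3c2)cc1` gives > 100000 nM, which is a limit of the assay and not a number. Compound 2 `Clc1ccccc1Cn1ccc2nc(-c3ccccc3)nc-2c1` stands in this assay at > 100000 nM, again a limit. Compound 3 `FC(F)(F)c1ccccc1Cn1ccc2nc(-c3ccccc3)nc-2c1` likewise reaches only a limit in this assay, at > 100000 nM. Going by the values given here, the steps a step that the two limits leave unreadable from compound 1 to compound 2 and a step that the two limits leave unreadable from compound 2 to compound 3 therefore show nothing beyond the fact that every value so far sits at the limit of > 100000 nM in this assay, at which 3 of the 3 values shown sit. Compound 4 `Clc1ccc(Cn2ccc3nc(-c4ccccc4)nc-3c2)cc1Cl` is the next member, and its change from compound 2 is 3,4-dichlorophenyl in place of 2-chlorophenyl on a saturated chain carbon bound to an aromatic nitrogen. Neither measured step gives a readable size, so no direction can be drawn from them. Compound 4 is expected to stay at the same limit, the expected step being a number no higher from compound 2 to compound 4 (the limit leaves the size open). The estimate for compound 4 in this assay is 100000 nM, with a range from 40000 nM to 300000 nM.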

Compound 4, half-maximal cytotoxic concentration: 71000 nM
Compound 4: middle estimate off by 1.4-fold (0.15 log units), on the high side, within the range that was stated.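

In this assay, going by these compounds alone, compound 4 is the first member to give a number and not a limit, so a change on the saturated chain carbon bound to an aromatic nitrogen can bring the read-out within the measurable range: the limit of > 100000 nM in this assay, at which 3 of the 4 values shown sit. The change reads as an at least 1.4-fold lower number from compound 2 to compound 4 (0.14 log units; that floor lies within the scatter), and as an at least 1.4-fold lower number from compound 1 to compound 4 (0.14 log units; that floor lies within the scatter). Neither floor lies beyond the scatter, so these steps show no firm drop.

From the compounds shown here alone, the true size of both steps stays open. So does whether an amine or a carboxylic acid in place of chloro would also give a number.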